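Phenyl Replacing Isopropyl on the Aryl Ether Oxygen

The compounds below may be only part of what the source reports. "The series", "measured", "known", "first", "only" and "open" are said of these compounds alone.

Compound 1 `CC(C)COc1cccc(-c2ccc(C(=O)N(Cc3cccc(OCCCCCC(=O)O)c3)C(C)C)cc2)c1` carries an isobutyl on an oxygen on an aromatic ring. In an ADME assay on HepG2 cells (Homo sapiens) for cytotoxicity, read by CellTiter-Glo and resazurin assay, with a stated time of 72 h (a lower number here means that less compound is needed, a higher number that more compound is needed for the effect), compound 1 reaches only the assay limit, > 26000 nM. Compound 2 `CC(C)Oc1cccc(-c2ccc(C(=O)N(Cc3cccc(OCCCCCC(=O)O)c3)C(C)C)cc2)c1` is related to it through a step that the two limits leave unreadable from compound 1 to compound 2. In this assay compound 2 also returns only a limit, > 26000 nM. So compound 2 stands at the limit of > 26000 nM in this assay, at which 2 of the 2 values shown sit, with no number of its own. Compound 3 `CC(C)N(Cc1cccc(OCCCCCC(=O)O)c1)C(=O)c1ccc(-c2cccc(Oc3ccccc3)c2)cc1` follows from compound 2 by phenyl in place of isopropyl on an oxygen on an aromatic ring. Among the compounds with values here, the single measured step bears on it but has no readable size, so no step beyond the scatter is expected, and the expected step is a step that the limit leaves unreadable from compound 2 to compound 3. Compound 3 is therefore expected to give 40000 nM, within 15000 nM to 120000 nM.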

Compound 3, half-maximal effective concentration: > 18700 nM
Compound 3: no number, only a limit (the forecaster's own chance of this, stated with the estimate: 85%); the middle value does not contradict the limit.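

Within the data shown here, compound 3 also returns only a limit, and no step among compound 1, compound 2 and compound 3 can be read in this assay. The compounds shown leave open at what concentration any of the three would reach its half-maximal effect.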